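Changing the Lactam Substituent of Compound 1

This account rests on a few compounds, and the source may have more. Where it says the series, first, only, none or still open, it means among the compounds named here.

Compound 1 `O=C1[C@@H](NS(=O)(=O)c2ccc(-c3ccc(Cl)s3)s2)CCN1CCNc1ccncc1` holds the higher of the two numbers recorded so far in an assay on isolated protein for inhibition of coagulation factor X (Oryctolagus cuniculus), tested at 0.1 uM; on this read-out higher numbers stand for more inhibition at the one concentration tested (going by the name of the read-out) and lower numbers for less inhibition. In this assay compound 1 gives 77%, while compound 2 `O=C1[C@@H](NS(=O)(=O)c2cc3ccc(Cl)cc3s2)CCN1CCNc1ccncc1`, which carries a different sulfonamide portion, gives 57%, a gap that lies beyond the usual scatter. Compound 3 `O=C1[C@@H](NS(=O)(=O)c2ccc(-c3ccc(Cl)s3)s2)CCN1Cc1cc2c[nH]ccc-2n1` has not yet been measured. It differs from compound 1 in a single place: a group of 9 heavy atoms (7 carbon, 2 nitrogen; one five-membered aromatic ring with 1 hetero atom, one six-membered aromatic ring with 1 hetero atom) in place of a group of 8 heavy atoms (6 carbon, 2 nitrogen; one six-membered aromatic ring with 1 hetero atom), on a saturated chain carbon bound to an amide-type nitrogen in a ring. For the measured compounds named here, no measured pair shows a step of this kind, so nothing about its size is known from the numbers in hand. A modest downward step, a number 12 percentage points lower from compound 1 to compound 3 (beyond the scatter), is expected for compound 3, because compound 1 already gives 77% and the replacement is a sizeable one. Compound 3 is therefore estimated at 65%, with a range from 30% to 90%.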

Compound 3, a percentage reported as inhibition, at one concentration (the size of the read-out at that concentration, not a potency): 62%
Estimate against measurement, compound 3: 3 percentage points above, and the stated range covers the measured number.
By their numbers in this assay, from the lowest: compounds 2 and 3 (each within the scatter of the next); then compound 1.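

For the compounds shown here, at the place on a saturated chain carbon bound to an amide-type nitrogen in a ring, the earlier compounds offered no comparison, since compound 1 and compound 2 differ in the sulfonamide portion. In this assay the exchange of ((pyridin-4-yl)amino)methyl for the group with a five-membered and a six-membered aromatic ring gives a number 15 percentage points lower from compound 1 to compound 3 (beyond the scatter) and so shows that this place responds to the change. Inhibition is reduced rather than lost, as compound 3 still gives 62% at the one concentration tested, and nothing available accounts for the drop.

The compounds shown leave open how a plain dimethylamino group or a carboxylic acid would fare at this place. They also leave open whether the same exchange would give a similar step with the sulfonamide portion of compound 2.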